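Cytotoxicity limit of compound 1 and its 2-methoxyethyl change

A few compounds are considered here, and "the series" means these few. Any claim that something is new, unique, unknown or untested is made for them only; others in the source may bear on it.

In an ADME assay on HepG2 2.2.15 cells (Homo sapiens) for cytotoxicity, read by MTT assay, with a stated time of 8 days (a higher number here means that more compound is tolerated, a lower number that less compound is tolerated), compound 1 (`CC(=O)Nc1ccc(-c2nn(Cc3ccc(C#N)cc3)c(=O)c3ccccc23)c(F)n1`) gives > 100000 nM, which is a limit of the assay and not a number. Compound 2 (`COC(=O)C1=C(C)NC(c2ncc(F)cc2F)=N[C@H]1c1ccc(F)cc1Cl`), a different structure, gives > 5000 nM, also a limit. Compound 3 (`COCCNc1ccc(-c2nn(Cc3ccc(C#N)cc3)c(=O)c3ccccc23)c(F)n1`) carries 2-methoxyethyl in place of acetyl on a nitrogen on an aromatic ring. Within the data shown here, no measured pair covers this change, and the starting point is only a limit. The expected change is an at least 1.6-fold lower number from compound 1 to compound 3 (0.22 log units; that floor lies within the scatter), toward less compound tolerated, and it may stay within the scatter. Compound 3 is estimated at 60000 nM, with an expected range of 20000 nM to 100000 nM.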

Compound 3, half-maximal cytotoxic concentration: > 100000 nM
Compound 3 ended at the assay's limit (the forecaster's own chance of this, stated with the estimate: 50%); middle value at least 1.6-fold (0.22 log units) away from the limit.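

In this assay compound 1 and compound 3 both stand at a limit and not at a number, and no step can be read between them. The compounds shown leave open whether 2-methoxyethyl in place of acetyl changes the tolerated concentration at all.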